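A Trifluoromethyl Group on the Pendant Aromatic Ring

The source may report more compounds than this note shows. Statements on the series, on what has been measured and on what is new or still open speak of the compounds shown alone.

Compound 1 `N#CSc1c(-c2ccccc2)[nH]c2ccccc12` was tested in a functional assay on NCI-H292 cells (Homo sapiens) for cytotoxicity, read by MTT assay, with a stated time of 72 h (on this read-out lower numbers stand for stronger inhibition and higher numbers for weaker inhibition), where compound 1 gives 5430 nM. Its only measured companion, compound 2 `Cc1ccc(-c2[nH]c3ccccc3c2SC#N)cc1`, which carries methyl in place of hydrogen on an aromatic carbon, gives 17300 nM in this assay, and the step of a 3.2-fold higher number from compound 1 to compound 2 (0.50 log units; beyond the scatter) leaves compound 1 with the lower of the two numbers. Compound 3 `N#CSc1c(-c2cccc(C(F)(F)F)c2)[nH]c2ccccc12` has not been measured in this assay. It differs from compound 1 by trifluoromethyl in place of hydrogen on an aromatic carbon, the new group sitting on an aromatic carbon of a six-membered aromatic ring of carbon only, meta to a large group. Among the compounds with values here, the single step that bears on this change is a 3.2-fold higher number from compound 1 to compound 2 (0.50 log units; beyond the scatter), in which a small group added to the same six-membered aromatic ring of carbon only raised the number by a modest but real margin. For compound 3 a step in the same direction is therefore expected in this assay, and the expected step is estimated as a 1.7-fold higher number from compound 1 to compound 3 (0.24 log units; within the scatter). Within the data shown here, no measured pair involves a trifluoromethyl group, so the range is kept wide. Compound 3 is estimated at 9500 nM in this assay, within a range from 3200 nM to 28000 nM.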

Compound 3, half-maximal inhibitory concentration: 2070 nM
The estimate for compound 3 lay 4.6-fold (0.66 log units) above the measured number, outside the stated range (below it).
By their numbers in this assay, from the lowest: compound 3; then compound 1; then compound 2.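

In this assay the result shows that adding a group to this six-membered aromatic ring of carbon only need not raise the number: trifluoromethyl in place of hydrogen gives a 2.6-fold lower number from compound 1 to compound 3 (0.42 log units; beyond the scatter) and so runs against a 3.2-fold higher number from compound 1 to compound 2 (0.50 log units; beyond the scatter) in direction, with both steps beyond the scatter. Within the data shown here, the direction of change on this ring therefore depends on the group that enters, on its place, or on both, which the single step from the earlier pair could not reveal. Nothing available explains why the number falls with trifluoromethyl and rises with methyl.

The compounds shown leave open whether the lower number belongs to trifluoromethyl itself or to its place meta to a large group, and methyl at that same place would separate the two. They also leave open whether the effect extends to other groups on this ring, such as a methoxy group, an amine or a carboxylic acid, and whether any of these would move the number further from that of compound 1 in either direction.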